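A few compounds are considered here, and "the series" means these few. Any claim that something is new, unique, unknown or untested is made for them only; others in the source may bear on it.

Measured compounds:
- Compound 1, `Cc1ccccc1-c1nn(-c2ccc(Cl)cc2)cc1CNCCN1CCN(C)CC1`, gives 17000 nM in an ADME assay on Huh-7 cells (Homo sapiens) for cytotoxicity; on this read-out higher numbers stand for lower toxicity in this test and lower numbers for higher toxicity in this test.
- Compound 2, `Cc1cccc(-c2nn(-c3ccc(F)cc3F)cc2CNCCN2CCN(C)CC2)c1`, reaches only the limit of this assay, > 20000 nM.
- Compound 3, `CCCN1CCC(CNCc2cn(-c3ccc([N+](=O)[O-])cc3)nc2-c2ccc(OC(F)(F)F)cc2)CC1`, gives 18000 nM in this assay.

Compound 1 stands at the lower of the two numbers shown, yet the value of compound 3 lies within the usual scatter of it, so the two cannot be told apart. The value of compound 2 is a limit of the assay and not a number.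

Compound 4, `Cc1ccccc1-c1nn(-c2ccc(C(F)(F)F)cc2)cc1CNCCN1CCN(C)CC1`, differs from compound 1 in one place: trifluoromethyl in place of chloro on an aromatic carbon. Going by the values given here, no measured pair shares this change, so there is nothing to set its size against. The step from compound 1 to compound 4 is expected to be no change at the digits printed from compound 1 to compound 4 (within the scatter), none beyond the scatter. Compound 4 is estimated at 17000 nM, between 7000 nM and 35000 nM.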

Compound 4, half-maximal cytotoxic concentration: 11000 nM
Compound 4: middle estimate off by 1.5-fold (0.19 log units), on the high side, and the stated range covers the measured number.
By their numbers in this assay, from the lowest: compounds 4, 1 and 3 (each within the scatter of the next). At a limit, above all of these: compound 2.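

Trifluoromethyl in place of chloro, on the aromatic carbon para to a large group, is the first change in one place here, and in this assay it gives a 1.5-fold lower number from compound 1 to compound 4 (0.19 log units; within the scatter). A group with more heavy atoms at this position therefore leaves compound 4 indistinguishable from compound 1. Any rise in the number could be followed only so far: the limit of > 20000 nM in this assay, at which 1 of the 4 values shown sits.

From the compounds shown here alone, whether an amine or a carboxylic acid at this position would move the number beyond the scatter stays open. So does whether this same change behaves alike on another core.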